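This account rests on a few compounds, and the source may have more. Where it says the series, first, only, none or still open, it means among the compounds named here.

Measured so far:
compound 1, `Cc1ccccc1-c1noc(-c2ccc(C3CCCCC3)cc2)n1`, gives 266 nM in a functional assay on CHO cells for agonist activity at sphingosine 1-phosphate receptor 5 (Homo sapiens), read by GTPgammaS binding; a higher number here means that more compound is needed for the effect, a lower number that less compound is needed
compound 2, `CC[C@H](C)Oc1ccc(-c2nc(-c3ccc(CCC(=O)O)cc3C)no2)cc1C#N`, gives 15 nM in this assay

Compound 2 holds the lower of the two numbers in this assay; compound 1 sits well above it, beyond the scatter. Compound 3, `Cc1cc(CCC(=O)O)ccc1-c1noc(-c2ccc(OCC(F)(F)F)c(C#N)c2)n1`, keeps the shared core and differs only by 2,2,2-trifluoroethyl in place of sec-butyl on an oxygen on an aromatic ring. Among the compounds with values here, no single-point step between measured compounds bears on this exchange. The expected step, a 1.7-fold higher number from compound 2 to compound 3 (0.22 log units; within the scatter), is small, within the scatter, if anything upward. Compound 3 is estimated in this assay at 25 nM, with a range from 8 nM to 80 nM.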

Compound 3, half-maximal effective concentration: 44 nM
Beside the measured number, compound 3's estimate is 1.8-fold (0.25 log units) below it, and the stated range covers the measured number.
By their numbers in this assay, from the lowest: compound 2; then compound 3; then compound 1.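

On an oxygen on an aromatic ring, 2,2,2-trifluoroethyl in place of sec-butyl gives a 2.9-fold higher number from compound 2 to compound 3 (0.47 log units; beyond the scatter) in this assay, a modest step beyond the scatter. Within the data shown here, this is the first single-point reading at this position, and it also removes the defined stereocentre of sec-butyl. Nothing measured here speaks to the cause of the step.

The compounds shown do not separate the effect of the fluorine atoms from that of losing the branched chain; ethyl or isopropyl on the same oxygen would bear on this. On these data alone, the opposite stereoisomer of sec-butyl also remains open.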